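Replacing the last benzyl group with 2-acetoxyethyl

The source may hold more compounds than are shown below. What is called first, only, known or untested is meant among the compounds shown, and "the series" means these compounds.

Measured so far in a functional assay on B16 cells (Mus musculus) for cytotoxicity, read by MTT assay, with a stated time of 48 h; a lower number here means a stronger inhibitor, a higher number a weaker inhibitor:
compound 1, `O=C(Nc1cccc(-c2cn(Cc3ccccc3)nn2)c1)c1cn(Cc2ccccc2)nn1`: 4500 nM
compound 2, `CC(=O)OCCn1cc(-c2cccc(NC(=O)c3cn(Cc4ccccc4)nn3)c2)nn1`: 25100 nM
compound 3, `CC(=O)OCCn1cc(C(=O)Nc2cccc(-c3cn(Cc4ccccc4)nn3)c2)nn1`: only a limit, > 100000 nM

Compounds 1 and 2 gave numbers inside the working range of this assay. Going by the values given here, compound 3 stands at the edge: its value is a limit of the assay, not a number, and it is the one value that sits at the limit of > 100000 nM in this assay, at which 1 of the 3 values shown sits. Of the three, compound 1 gives the lowest number, compound 2 a higher one, and compound 3 only the limit.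

Compound 4, `CC(=O)OCCn1cc(C(=O)Nc2cccc(-c3cn(CCOC(C)=O)nn3)c2)nn1`, differs from compound 3 in one place: acetoxymethyl in place of phenyl on a saturated chain carbon bound to an aromatic nitrogen. This same change has been measured twice already, each time starting from compound 1: a 5.6-fold higher number from compound 1 to compound 2 (0.75 log units; beyond the scatter) and an at least 22-fold higher number from compound 1 to compound 3 (1.34 log units; beyond the scatter). Both steps moved the number upward, and both were beyond the scatter. The same change applied to compound 3 is therefore expected to push the number upward once more, or at best leave it at the limit, giving an expected step that the limit leaves unreadable from compound 3 to compound 4. Compound 4 is expected to give 300000 nM, with a range from 100000 nM to 1000000 nM, and most probably the assay would again report only a limit.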

Compound 4, half-maximal inhibitory concentration: > 100000 nM
Compound 4: a limit, no number; the forecaster's own chance of this, stated with the estimate: 85%; the middle value lies beyond the limit too.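

The same change at the same place, on a saturated chain carbon bound to an aromatic nitrogen, now also weakens a compound that already carries one 2-acetoxyethyl group: in this assay, swapping benzyl for 2-acetoxyethyl gives an at least 3.9-fold higher number from compound 2 to compound 4 (0.60 log units; beyond the scatter). The loss therefore appears on two different starting compounds, not just on compound 1: the same change on two cores in this assay, an at least 22-fold higher number (1.34 log units; beyond the scatter) from compound 1 to compound 3 and an at least 3.9-fold higher number (0.60 log units; beyond the scatter) from compound 2 to compound 4; the limit leaves it open whether they differ The step from compound 3 to compound 4 cannot be read, so replacing the other benzyl group tells nothing about its effect on the number, and the read-out has no room left to show further weakening in this small set: the limit of > 100000 nM in this assay, at which 2 of the 4 values shown sit.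

The compounds shown leave open how far beyond the limit compound 3 and compound 4 lie, and whether the weakening follows from losing the phenyl ring or from gaining the acetoxy group. A 2-hydroxyethyl chain, a chain ending in an amine or a carboxylic acid, or a longer chain ending in phenyl at this place could begin to separate those two possibilities.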